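A few compounds are considered here, and "the series" means these few. Any claim that something is new, unique, unknown or untested is made for them only; others in the source may bear on it.

In a functional assay on A549 cells (Homo sapiens) for inhibition, read by MTT assay, with a stated time of 72 h (a lower number here means a stronger inhibitor, a higher number a weaker inhibitor), compound 2, with the structure `CN(C(=O)NC(=O)c1c(F)cccc1F)c1nc(C(F)(F)F)c(C(=O)N/N=C/c2cc(C(F)(F)F)cc(C(F)(F)F)c2)s1`, gives 17.3 ug/mL. Among the compounds with values here, this is the higher of the two numbers measured so far: compound 1, with the structure `CN(C(=O)NC(=O)c1ccc(Cl)c(Cl)c1)c1nc(C(F)(F)F)c(C(=O)N/N=C/c2ccc([N+](=O)[O-])cc2)s1`, gives 6.44 ug/mL in this assay, and the gap between these two values lies beyond the scatter of repeated measurements. Compound 1 and compound 2 differ in more than one place, so nothing can be read from their pair about any single change.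

Compound 3, with the structure `CN(C(=O)NC(=O)c1ccc(F)c(F)c1)c1nc(C(F)(F)F)c(C(=O)N/N=C/c2cc(C(F)(F)F)cc(C(F)(F)F)c2)s1`, has not yet been measured in this assay. It differs from compound 2 in a single way: 3,4-difluorophenyl in place of 2,6-difluorophenyl on a carbonyl carbon. Within the data shown here, no measured pair in this set shows what this change does. The step from compound 2 to compound 3 is therefore expected to be small, a 1.2-fold lower number from compound 2 to compound 3 (0.06 log units; within the scatter), lying within the usual scatter rather than beyond it. For compound 3 the estimate in this assay is 15 ug/mL, with a range from 6 ug/mL to 40 ug/mL.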

Compound 3, half-maximal inhibitory concentration: 5.47 ug/mL
Compound 3: middle estimate off by 2.7-fold (0.44 log units), on the high side; the whole stated range lies above it.
By their numbers in this assay, from the lowest: compounds 3 and 1 (each within the scatter of the next); then compound 2.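

Within the data shown here, replacing 2,6-difluorophenyl with 3,4-difluorophenyl on a carbonyl carbon whose other neighbour is an amide-type nitrogen gives a 3.2-fold lower number from compound 2 to compound 3 (0.50 log units; beyond the scatter) in this assay, the first comparison in this set that isolates a single change. The two compounds have the same atoms, joined differently, so the number at this position shifts with the placement of the two fluorines alone. Nothing available explains this shift.

A single pair cannot show whether the same step would recur with a different group elsewhere on the shared core. The compounds shown also leave open how an unsubstituted phenyl, a pyridyl ring or a cyclohexyl group would behave on this carbonyl carbon.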